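An Amide in Place of an Ester on a Shared Core

A few compounds are considered here, and "the series" means these few. Any claim that something is new, unique, unknown or untested is made for them only; others in the source may bear on it.

Measured compounds:
compound 1, `COC(=O)C1=C(C)NC(=O)NC1c1ccoc1`: 2%
compound 2, `COC(=O)C1=C(C)NC(=O)NC1c1cccs1`: 3%
compound 3, `COC(=O)C1=C(C)N(C)C(=O)NC1c1ccoc1`: 7%

In an assay on membranes from HeLa cells for displacement of a labelled ligand from adenosine receptor A3 (Homo sapiens), read by scintillation counting, with a stated time of 180 min, tested at 1 uM (a higher number here means more inhibition at the concentration tested (going by the name of the read-out), a lower number less inhibition), compound 1 gives 2%. This is the smallest of the three numbers, yet neither of the others stands apart from it: the step of a number 1 percentage points higher from compound 1 to compound 2 (within the scatter) and the step of a number 5 percentage points higher from compound 1 to compound 3 (within the scatter) both lie within the scatter, so the three compounds are indistinguishable on this read-out.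

Compound 4, `CC1=C(C(N)=O)C(c2ccoc2)NC(=O)N1`, differs from compound 1 in one place:

amino in place of methoxy on a carbonyl carbon

Within the data shown here, no measured step touches the carbonyl carbon or what hangs from it; the two known steps changed the aromatic ring and the ring nitrogen, and each stayed within the scatter. The shared core therefore has shown no response to any change so far, and nothing in the data points to a different outcome here. The step of a number 2 percentage points higher from compound 1 to compound 4 (within the scatter) is accordingly expected to stay within the scatter. For compound 4 in this assay the estimated value is 4%, with a range from -8% to 16%.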

Compound 4, a percentage reported as inhibition, at one concentration (the size of the read-out at that concentration, not a potency): 2%
For compound 4 the middle estimate is 2 percentage points above the measured one, within the range that was stated.
By their numbers in this assay, from the lowest: compounds 1, 4, 2 and 3 (each within the scatter of the next).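

In this assay, among these compounds, the first change at the carbonyl carbon, methoxycarbonyl to carbamoyl, reads as no change at the digits printed from compound 1 to compound 4 (within the scatter), so a hydrogen-bond donor entering on amino and a hydrogen-bond acceptor leaving on methoxy register nothing on this read-out. The carbonyl carbon thus joins the aromatic ring and the ring nitrogen as a third place on the shared core where a single change stays within the scatter, and all four compounds remain indistinguishable. Nothing shown gives any reason for this outcome. The compounds shown leave open whether a carboxylic acid, a methylamino group or a longer alkoxy chain on the carbonyl carbon would move the read-out beyond the scatter. They also leave open whether amino in place of methoxy would matter on a compound of this series that shows clear inhibition.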